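Swapping the aryl group on the shared core

The compounds below may be only part of what the source reports. "The series", "measured", "known", "first", "only" and "open" are said of these compounds alone.

Measured so far:
compound 1, `C#Cc1cccc(Nc2ncnc3cc(OC)c(OCCCN4CCNCCNCCNCC4)cc23)c1`: 1110 nM
compound 2, `COc1cc2ncnc(Nc3cccc(Br)c3)c2cc1OCCCN1CCNCCNCCNCC1`: 1050 nM
compound 3, `COc1cc2ncnc(Nc3ccc(F)c(Br)c3)c2cc1OCCCN1CCNCCNCCNCC1`: 1580 nM

All three compounds were tested in a functional assay on A-431 cells (Homo sapiens) for antiproliferative activity, read by MTT assay, with a stated time of 72 h; on this read-out lower numbers stand for stronger inhibition and higher numbers for weaker inhibition. In this assay compound 2 gives 1050 nM, the lowest of the three numbers, but its gap to compound 1, a 1.1-fold lower number from compound 1 to compound 2 (0.02 log units; within the scatter), and to compound 3, a 1.5-fold higher number from compound 2 to compound 3 (0.18 log units; within the scatter), both fall inside the scatter, so the three compounds cannot be ranked against one another.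

Compound 4, `CCc1cc(Br)ccc1Nc1ncnc2cc(OC)c(OCCCN3CCNCCNCCNCC3)cc12`, has not been measured. It differs from compound 2 in one place: 4-bromo-2-ethylphenyl in place of 3-bromophenyl on a nitrogen on an aromatic ring

The steps known so far all alter the same aromatic ring on the nitrogen of the shared core: a 1.1-fold lower number from compound 1 to compound 2 (0.02 log units; within the scatter), a 1.4-fold higher number from compound 1 to compound 3 (0.15 log units; within the scatter) and a 1.5-fold higher number from compound 2 to compound 3 (0.18 log units; within the scatter). None of them moved the number beyond the scatter. Among the compounds with values here, the change to compound 4 is larger than any of those, replacing the whole 3-bromophenyl by 4-bromo-2-ethylphenyl, and no measured pair shows this exact change, so the expectation rests only on the general insensitivity seen so far.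

Compound 4 is therefore expected to give 2000 nM in this assay, with a plausible range from 700 nM to 6000 nM. This estimate means a step of a 1.9-fold higher number from compound 2 to compound 4 (0.28 log units; within the scatter), a mild weakening allowed for because the change is larger than those behind a 1.5-fold higher number from compound 2 to compound 3 (0.18 log units; within the scatter).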

Compound 4, half-maximal inhibitory concentration: 5650 nM
Beside the measured number, compound 4's estimate is 2.8-fold (0.45 log units) below it, and the stated range covers the measured number.
By their numbers in this assay, from the lowest: compounds 2, 1 and 3 (each within the scatter of the next); then compound 4.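

In this assay, within the data shown here, the aromatic group on the nitrogen of the shared core proves not to be free to change: 4-bromo-2-ethylphenyl in place of 3-bromophenyl gives the first step here beyond the scatter (a 5.4-fold higher number from compound 2 to compound 4 (0.73 log units; beyond the scatter)). Among these compounds, the same holds when 4-bromo-2-ethylphenyl replaces 3-bromo-4-fluorophenyl (a 3.6-fold higher number from compound 3 to compound 4 (0.55 log units; beyond the scatter)) or 3-ethynylphenyl (a 5.1-fold higher number from compound 1 to compound 4 (0.71 log units; beyond the scatter)), whereas the swaps among those three groups all stayed within the scatter, so tolerance at this place has a limit that the earlier compounds did not reveal. No measurement shown here explains why the number rises with this change.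

The names of the two groups show that the bromo and the ethyl change together, and this single step cannot tell which of the two matters, or whether both do. Also open, from the compounds shown here alone, is how the number would respond to a methyl or a longer chain in place of the ethyl, or to an amine or a hydroxyl in place of the bromo.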